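From hydroxy to 2-oxopyrrolidin-1-yl on the chain

The source may hold more compounds than are shown below. What is called first, only, known or untested is meant among the compounds shown, and "the series" means these compounds.

Measured so far in an ADME assay (liver) for metabolic stability, with Liver microsome (Rattus norvegicus) as the target, read by LC-MS, using microsomes, with a stated time of 30 min, tested at 4 uM; on this read-out lower numbers stand for a less stable compound and higher numbers for a more stable compound:
- compound 1 `Cc1nc(N2CCN(C)CC2)c2nc(-c3ccccc3Cl)n(CCO)c2n1` gives 6% remaining
- compound 2 `CCN1CCN(c2nc(C)nc3c2nc(-c2ccccc2Cl)n3CCOC)CC1` gives 53% remaining

Compound 1 stands lowest of these two, and the gap up to compound 2 lies beyond the scatter. Compound 3 `Cc1nc(N2CCN(C)CC2)c2nc(-c3ccccc3Cl)n(CCN3CCCC3=O)c2n1` carries 2-oxopyrrolidin-1-yl in place of hydroxy on a saturated chain carbon, two bonds along the chain from an aromatic nitrogen. For the measured compounds named here, no measured pair shows this change alone. Compound 2, which also lacks the hydroxy but differs elsewhere, reaches 53% in this assay and so hints at room upward. An upward step beyond the scatter is expected, estimated as a number 19 percentage points higher from compound 1 to compound 3 (beyond the scatter) overall. For compound 3 the estimate is 25% with an expected range from 8% to 50% remaining.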

Compound 3, percent of the compound remaining: 28%
The estimate for compound 3 lay 3 percentage points below the measured number; measured number inside the range.
By their numbers in this assay, from the lowest: compound 1; then compound 3; then compound 2.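

With all else in compound 1 kept, putting 2-oxopyrrolidin-1-yl in place of hydroxy on a saturated chain carbon, two bonds along the chain from an aromatic nitrogen, gives a number 22 percentage points higher from compound 1 to compound 3 (beyond the scatter) in this assay. For the compounds shown here, this is the first single-place step, and it shows that the read-out responds to what sits at this position. Nothing measured here explains the step.

The compounds shown leave open whether losing the hydroxy or gaining the ring matters more. As far as these compounds go, how a methoxy, an amine or a carboxylic acid on this chain, or a longer chain, would compare also remains open.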